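Swapping a halogen on a quinoline-like side chain

The compounds below may be only part of what the source reports. "The series", "measured", "known", "first", "only" and "open" are said of these compounds alone.

The shared core carries a butynyl chain, an aminopiperidine and a benzyl-type group on the second ring nitrogen. Compound 1 `CC#CCn1c(N2CCC[C@@H](N)C2)cc(=O)n(Cc2ccccc2)c1=O` has a plain benzyl group there; compound 2 `CC#CCn1c(N2CCC[C@@H](N)C2)cc(=O)n(Cc2ccc3cc(Cl)ccc3n2)c1=O` instead carries a chloro-bearing fused two-ring system. In an assay on isolated protein for inhibition of Dipeptidyl peptidase 9 (Homo sapiens) (a higher number here means a weaker inhibitor, a lower number a stronger inhibitor), compound 1 reports only a limit, > 100000 nM. In this assay compound 2 likewise reports only a limit, > 100000 nM. Compound 2 therefore stands where every value shown stands: both results sit at the limit of > 100000 nM in this assay, at which 2 of the 2 values shown sit, so no ranking between them is possible. Compound 3 `CC#CCn1c(N2CCC[C@@H](N)C2)cc(=O)n(Cc2ccc3cc(F)ccc3n2)c1=O` differs from compound 2 by fluoro in place of chloro on an aromatic carbon. For the measured compounds named here, with no measured step to lean on, the change from compound 2 to compound 3 is expected to be small, a step that the limit leaves unreadable from compound 2 to compound 3, with no direction beyond the scatter. Compound 3 is estimated at 120000 nM, between 40000 nM and 400000 nM.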

Compound 3, half-maximal inhibitory concentration: > 100000 nM
Compound 3 ended at the assay's limit; the forecaster's own chance of this, stated with the estimate: 85%; the middle value does not contradict the limit.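

No step can be read from compound 2 to compound 3, since each result is only a limit, not a number: the limit of > 100000 nM in this assay, at which 3 of the 3 values shown sit. The compounds shown leave open whether fluoro and chloro on this side chain differ at all in this assay.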